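Trimming the hydrazone aryl group to a methyl

The source may report more compounds than this note shows. Statements on the series, on what has been measured and on what is new or still open speak of the compounds shown alone.

Measured compounds:
compound 1, `CC1CCC(=NNc2cc(Cl)cc(Cl)c2)c2ncc(C(=O)O)c(=O)n21`, 13.3 umol/kg
compound 2, `CC1CCC(=NNc2ccccn2)c2ncc(C(=O)O)c(=O)n21`, 3.2 umol/kg

Within the data shown here, in a functional assay on the whole organism with Rattus norvegicus as the target (on this read-out lower numbers stand for an effect already at smaller amounts and higher numbers for an effect only at larger amounts of compound), compound 2 gives the lowest of the two numbers; the only neighbour is compound 1, and the step of a 4.2-fold lower number from compound 1 to compound 2 (0.62 log units; beyond the scatter) came with pyridin-2-yl in place of 3,5-dichlorophenyl on an amine nitrogen. Compound 3, `CNN=C1CCC(C)n2c1ncc(C(=O)O)c2=O`, is not yet measured. It differs from compound 2 by methyl in place of pyridin-2-yl on an amine nitrogen. Among the measured compounds shown here, the one measured step swaps one six-membered aromatic ring for another, so it does not show what happens when the ring is removed altogether. For the measured compounds named here, no measured step bears directly on that change. With an aromatic ring leaving, a higher number for compound 3 than for compound 2 is expected, and a step of size a 4.7-fold higher number from compound 2 to compound 3 (0.67 log units; beyond the scatter) is estimated. For compound 3 a value of 15 umol/kg is expected, with a range from 4 umol/kg to 60 umol/kg.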

Compound 3, dose for 50% inhibition: 17.5 umol/kg
Estimate against measurement, compound 3: 1.2-fold (0.07 log units) below; measured number inside the range.
By their numbers in this assay, from the lowest: compound 2; then compounds 1 and 3 (each within the scatter of the next).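

In this assay, replacing the ring with methyl gives a 5.5-fold higher number from compound 2 to compound 3 (0.74 log units; beyond the scatter), so the pyridin-2-yl group on this amine nitrogen goes with an effect at smaller amounts than a methyl does, something the swap between two aromatic rings could not show. The picture differs for 3,5-dichlorophenyl: a 1.3-fold higher number from compound 1 to compound 3 (0.12 log units; within the scatter) leaves compound 1 and compound 3 level within the scatter. Having an aromatic ring at this place is therefore not enough in itself to separate a compound from the methyl compound, and among these three compounds only the pyridin-2-yl group stands apart.

From the compounds shown here alone, it remains open where a plain phenyl ring, a pyridin-3-yl ring or a longer chain such as ethyl would fall on this scale. Nothing available here explains why the two rings differ.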